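Replacing Trifluoromethyl with 3-Fluorooxetan-3-yl

The source may report more compounds than this note shows. Statements on the series, on what has been measured and on what is new or still open speak of the compounds shown alone.

Compound 1 (`Cc1cc(COc2cc(F)c(F)c(F)c2)nc(-c2ccccn2)n1`) gives 3.4 in a physicochemical assay for lipophilicity, at pH 7.4 (a lower number here means a more polar compound, a higher number a more lipophilic compound), and compound 2 (`CN(C)c1cc(COc2cccc(F)c2)nc(-c2ccccn2)n1`) gives 3.6 in the same measurement, two values within the usual scatter of each other. For compound 3 (`Fc1ccc(OCc2cc(OCC(F)(F)F)nc(-c3ccccn3)n2)c(F)c1F`) the reading is > 4.9 and this is a limit of the assay, not a number.

Compound 4 (`Fc1ccc(OCc2cc(OCC3(F)COC3)nc(-c3ccccn3)n2)c(F)c1F`) has not been measured yet. It carries a single change from compound 3, with 3-fluorooxetan-3-yl in place of trifluoromethyl on a saturated chain carbon bound to an oxygen on an aromatic ring. The entering group has 1 hydrogen-bond acceptor and one four-membered non-aromatic ring, while the leaving group has neither.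

Among the measured compounds shown here, no measured pair of compounds shows this exchange, so a clear step down in this assay, beyond the usual scatter, remains an expectation. The expected size is a number at least 1.00 log units lower from compound 3 to compound 4 (beyond the scatter) on this estimate. Compound 4 is estimated at 3.9 with an expected range from 3.3 to 4.5 once it is measured.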

Compound 4, distribution coefficient: 4
Beside the measured number, compound 4's estimate is 0.10 log units below it, within the range that was stated.
By their numbers in this assay, from the lowest: compounds 1 and 2 (each within the scatter of the next); then compound 4. At a limit, above all of these: compound 3.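

With compound 4, this position gives a real reading in this assay: compound 4 gives 4, where the earlier trifluoromethyl compound offered no number. The exchange of trifluoromethyl for 3-fluorooxetan-3-yl on this chain produces the first step measured here, a number at least 0.90 log units lower from compound 3 to compound 4 (beyond the scatter). That step sets only a minimum and not an exact size, because compound 3 stands at a limit of the assay: the limit of > 4.9 in this assay, at which 1 of the 4 values shown sits.

The exchange adds the four-membered ring and its oxygen and removes fluorine atoms in one move, and the compounds shown do not separate these parts of the change. On these data alone, a plain oxetan-3-yl without fluorine, a cyclobutyl ring or an amine at this place would be needed to show which part carries the step, and how far it holds on another core remains open too.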